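Furan-2-yl for furan-3-yl: three limits, one unmeasured

The source may report more compounds than this note shows. Statements on the series, on what has been measured and on what is new or still open speak of the compounds shown alone.

compound 1 `Cc1nc(N)c2c(-c3ccco3)cn([C@@H]3O[C@H](CO)[C@@H](O)[C@H]3O)c2n1`: in a functional assay on K562 cells (Homo sapiens), read by MTT assay, with a stated time of 72 h (a higher number here means a weaker inhibitor, a lower number a stronger inhibitor), compound 1 gives > 20000 nM, which is a limit of the assay.
compound 2 `COc1nc(N)nc2c1c(-c1ccoc1)cn2[C@@H]1O[C@H](CO)[C@@H](O)[C@H]1O`: in this assay compound 2 gives > 20000 nM, again a limit of the assay.
compound 3 `Cc1nc(N)c2c(-c3ccoc3)cn([C@@H]3O[C@H](CO)[C@@H](O)[C@H]3O)c2n1`: in this assay compound 3 gives > 20000 nM, also a limit of the assay.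

Compound 4 `COc1nc(N)nc2c1c(-c1ccco1)cn2[C@@H]1O[C@H](CO)[C@@H](O)[C@H]1O` has not been measured in this assay. It differs from compound 2 by furan-2-yl in place of furan-3-yl on an aromatic carbon. The same change is made from compound 3 to compound 1; its size is a step that the two limits leave unreadable from compound 3 to compound 1, the change being (furan-2-yl in place of furan-3-yl on an aromatic carbon). How the core of compound 2 differs from the core of compound 3 is not broken down here.

Within the data shown here, all three values sit at the limit of > 20000 nM in this assay, at which 3 of the 3 values shown sit, so no step has a readable size. For compound 4 the expected step is a step that the limit leaves unreadable from compound 2 to compound 4, resting on the unreadable precedent from compound 3 to compound 1 and on compound 2 giving > 20000 nM. Compound 4 is therefore expected to give about 30000 nM, estimated between 10000 nM and 100000 nM, most likely reported as a limit.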

Compound 4, half-maximal inhibitory concentration: > 20000 nM
Compound 4: no number, only a limit (the forecaster's own chance of this, stated with the estimate: 85%); the middle value lies beyond the limit too.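

No step can be read between compound 2 and compound 4, nor between compound 3 and compound 1, because all four compounds sit at a limit of the assay: the limit of > 20000 nM in this assay, at which 4 of the 4 values shown sit.

The compounds shown leave open whether furan-2-yl and furan-3-yl differ at all in this assay, and how the core of compound 2 compares with the core of compound 3.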